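Swapping the aryl group on the ring amine

This account rests on a few compounds, and the source may have more. Where it says the series, first, only, none or still open, it means among the compounds named here.

Of the compounds shown here, three sharing one core have been measured in an assay on HEK293 cells for inhibition of Voltage-dependent T-type calcium channel subunit alpha-1G (Homo sapiens), read by fluorescence, tested at 10 uM; on this read-out lower numbers stand for less inhibition and higher numbers for more inhibition at the one concentration tested (going by the name of the read-out). Compound 1 `CCCc1nc(-c2ccccc2)c(CNCCCN2CCN(c3ccccc3F)CC2)o1` gives 54.4%. Compound 2 `CCCc1nc(-c2ccccc2)c(CNCCN2CCN(c3ccccc3F)CC2)o1` differs from compound 1 only in the length of the linking chain, and compound 2 gives 46.5%. Compound 3 `CCCc1nc(-c2ccccc2)c(CNCCCN2CCN(c3ccccc3Cl)CC2)o1` gives 64.7%. Within the data shown here, the one single-point step among them, a number 10.3 percentage points higher from compound 1 to compound 3 (beyond the scatter), is a modest rise beyond the scatter. Compound 2 shows the lowest of the three numbers: compound 1 lies nearest, its value higher but within the scatter, while compound 3 lies furthest, its value higher by more than the scatter.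

The next compound, compound 4 `CCCc1nc(-c2ccccc2)c(CNCCN2CCN(c3ccc(OC)cc3)CC2)o1`, is built from compound 2 by the change (4-methoxyphenyl in place of 2-fluorophenyl on an amine nitrogen in a ring). Among the measured compounds shown here, no measured step bears directly on this exchange; the only step seen, the chloro for fluoro exchange, altered this assay modestly. With nothing to suggest a large shift either way, and with the fluorine gone rather than replaced by chlorine, compound 4 is expected to give 46% in this assay, in a range from 26% to 66%. That estimate means a step of a number 0.5 percentage points lower from compound 2 to compound 4 (within the scatter), expected to remain within the scatter.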

Compound 4, a percentage reported as inhibition, at one concentration (the size of the read-out at that concentration, not a potency): 51.5%
Estimate against measurement, compound 4: 5.5 percentage points below, within the range that was stated.
By their numbers in this assay, from the lowest: compounds 2, 4 and 1 (each within the scatter of the next); then compound 3.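

In this assay, the exchange of the whole aryl group on the ring amine nitrogen gives a number 5 percentage points higher from compound 2 to compound 4 (within the scatter) and so does not separate the two compounds, although 4-methoxyphenyl carries one hydrogen-bond acceptor and 2-fluorophenyl carries none. Unlike the earlier step, a number 10.3 percentage points higher from compound 1 to compound 3 (beyond the scatter) on the linking chain of compound 1, which kept a halogen on the same aryl ring, this one shows that on the linking chain of compound 2 the halogen can give way to a methoxy group without a shift beyond the scatter. No measurement offered here explains this result.

Because the fluorine leaves and the methoxy group enters in a single step, the compounds shown do not tell what each of these changes contributes alone, and a plain phenyl or a 2-methoxyphenyl on the same nitrogen would help to divide them. Going by these compounds, it also stays open whether 4-methoxyphenyl would read the same way on the linking chain of compound 1, where the chloro for fluoro exchange moved the number beyond the scatter.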